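The source may report more compounds than this note shows. Statements on the series, on what has been measured and on what is new or still open speak of the compounds shown alone.

The measured compounds and their values in an assay on the whole organism (stomach) for inhibition of Catechol O-methyltransferase (Mus musculus), with a stated time of 1 h, at a dose of 30 mg/kg by the oral route; a higher number here means more inhibition at the dose given (going by the name of the read-out), a lower number less inhibition:
compound 1, `O=C(COc1ccccc1)c1cc(O)c(O)c([N+](=O)[O-])c1`, 78%;
compound 2, `CCN(CC)CCC(=O)c1cc(O)c(O)c([N+](=O)[O-])c1`, 62%;
compound 3, `O=C(COc1cccc2ccccc12)c1cc(O)c(O)c([N+](=O)[O-])c1`, 86%.

Compound 1 stands second highest of these three numbers. Its nearest neighbour is compound 3, whose value lies within the scatter of that of compound 1; its furthest is compound 2, reached by the step of a number 16 percentage points lower from compound 1 to compound 2 (beyond the scatter), which lies beyond the scatter. Compound 4, `COc1ccc(OCC(=O)c2cc(O)c(O)c([N+](=O)[O-])c2)cc1`, has not yet been measured in this assay. It differs from compound 1 in one place: methoxy in place of hydrogen on an aromatic carbon. Among the measured compounds shown here, the only measured step, from compound 1 to compound 2, exchanges the whole phenoxy group and so bears only loosely on the entry of methoxy on an aromatic carbon; the pair of compound 1 and compound 3 shows that a change at that end of the molecule can leave the value within the scatter. A step of modest size, or none beyond the scatter, is therefore expected in this assay. Compound 4 is estimated to give 80%, between 68% and 90%, which is the expected step of a number 2 percentage points higher from compound 1 to compound 4 (within the scatter).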

Compound 4, a percentage reported as inhibition, in the whole organism at one dose (the size of the read-out at that dose, not a potency): 71%
The estimate for compound 4 lay 9 percentage points above the measured number; low and high end bracket the measured number.
By their numbers in this assay, from the lowest: compounds 2, 4, 1 and 3 (each within the scatter of the next, the first and the last beyond it).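

In this assay, the entry of methoxy on an aromatic carbon, para to a large group, gives the step of a number 7 percentage points lower from compound 1 to compound 4 (within the scatter). Among the compounds shown here, this is the first reading of a single added group at this position, whereas the earlier compounds changed that end of the molecule as a whole, and it shows that this position accepts methoxy with no step beyond the scatter. Nothing among the data given bears on the reason for this result.

From the compounds shown here alone, whether the same holds for a group of another kind at this position, such as an amine, a carboxylic acid or a longer alkoxy chain, stays open. Also open, going by these compounds, is how methoxy would read on the other aromatic carbons of the phenoxy group.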